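Dimethylamino for methyl on the aryl ring, meta case

The source may hold more compounds than are shown below. What is called first, only, known or untested is meant among the compounds shown, and "the series" means these compounds.

Measured so far:
- compound 1 `CN(C)c1ccc(-c2nc3c(=O)n(C)c(=O)n(C)c3[nH]2)cc1`, an assay for binding affinity to adenosine receptor A1 (Bos taurus); a lower number here means a stronger inhibitor, a higher number a weaker inhibitor: 1.8 nM
- compound 2 `Cc1ccc(-c2nc3c(=O)n(C)c(=O)n(C)c3[nH]2)cc1`, this assay: 0.8 nM
- compound 3 `Cc1cccc(-c2nc3c(=O)n(C)c(=O)n(C)c3[nH]2)c1`, this assay: 13 nM

Compound 2 and compound 3 are built from the same atoms joined differently; the difference between the two cores is not broken down here. Compound 3 carries the highest number of the three, and its gap to each of the other two is beyond the scatter.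

One exchange on the aryl ring is measured: a 2.3-fold higher number from compound 2 to compound 1 (0.35 log units; beyond the scatter), the change being (dimethylamino in place of methyl on an aromatic carbon).

Compound 4 `CN(C)c1cccc(-c2nc3c(=O)n(C)c(=O)n(C)c3[nH]2)c1` is not yet measured. It arises from compound 3 by dimethylamino in place of methyl on an aromatic carbon. This is the same kind of change as from compound 2 to compound 1, not the same: in the measured case the group sits para to a large group, in compound 4 meta to a large group.

Going by the values given here, for compound 4 in this assay a step of about a 2.3-fold higher number from compound 3 to compound 4 (0.36 log units; beyond the scatter) is expected, because a 2.3-fold higher number from compound 2 to compound 1 (0.35 log units; beyond the scatter) is the only measured example of this exchange and the meta setting adds uncertainty. Compound 4 is thus estimated at 30 nM, within a range from 10 nM to 90 nM.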

Compound 4, half-maximal inhibitory concentration: 80 nM
Beside the measured number, compound 4's estimate is 2.7-fold (0.43 log units) below it, and the stated range covers the measured number.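

In this assay, dimethylamino in place of methyl on an aromatic carbon gives a 6.2-fold higher number from compound 3 to compound 4 (0.79 log units; beyond the scatter), so the number rises on both cores shown. The direction of the change carries over between these two pairs, but its size does not: the same change on two cores in this assay, a 2.3-fold higher number (0.35 log units; beyond the scatter) from compound 2 to compound 1 and a 6.2-fold higher number (0.79 log units; beyond the scatter) from compound 3 to compound 4, 2.7-fold (0.44 log units) apart, beyond the scatter of two such steps. Two pairs cannot show why the steps differ, whether the cause lies in the group sitting meta to a large group in compound 4 or elsewhere, and they give no basis for assigning a step size to any further core.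

The compounds shown leave open how an unsubstituted amine, a methoxy group or a carboxylic acid in the same place would compare with methyl and dimethylamino on each core. As far as these compounds go, it also remains open whether a longer chain on the nitrogen, such as diethylamino, would widen or narrow the gap between the two steps.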